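Swapping chloro for cyano on a shared indole-free core? No — a cautious guess

A few compounds are considered here, and "the series" means these few. Any claim that something is new, unique, unknown or untested is made for them only; others in the source may bear on it.

Of the compounds shown here, three built on one shared core have been tested in a functional assay on HL-60 cells (Homo sapiens) for antiproliferative activity, read by MTT assay, with a stated time of 72 h; on this read-out higher numbers stand for weaker inhibition and lower numbers for stronger inhibition. Compound 1 `CN(C(=O)c1ccccc1)c1ccc2[nH]c(-c3n[nH]c4ccccc34)cc2n1` gives 4850 nM. Compound 2 `CN(C(=O)c1ccc([N+](=O)[O-])cc1)c1ccc2[nH]c(-c3n[nH]c4ccccc34)cc2n1` gives 6800 nM, and compound 3 `CN(C(=O)c1ccccc1)c1ccc2[nH]c(-c3n[nH]c4cc(Cl)ccc34)cc2n1` gives 5620 nM. Compound 3 thus sits within the usual scatter of both other compounds, so none of the three can be called stronger or weaker than another on these numbers.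

Two single changes have been measured so far. Adding a nitro group gave a 1.4-fold higher number from compound 1 to compound 2 (0.15 log units; within the scatter), and adding a chloro group gave a 1.2-fold higher number from compound 1 to compound 3 (0.06 log units; within the scatter). Neither change moved this assay beyond its scatter.

Compound 4 `CN(C(=O)c1ccccc1)c1ccc2[nH]c(-c3n[nH]c4cc(C#N)ccc34)cc2n1` differs from compound 3 by cyano in place of chloro on an aromatic carbon. Nothing measured here speaks directly to cyano at this place, but the two changes that have been measured, a nitro group and a chloro group on aromatic carbons, each stayed within the scatter. The expectation therefore is a step of a 1.0-fold lower number from compound 3 to compound 4 (0.01 log units; within the scatter), which is to say no change that the assay could reliably resolve. On that basis compound 4 is estimated to give about 5500 nM in this assay, with a plausible range from 2500 nM to 12000 nM.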

Compound 4, half-maximal inhibitory concentration: 6430 nM
Compound 4: middle estimate off by 1.2-fold (0.07 log units), on the low side; low and high end bracket the measured number.
By their numbers in this assay, from the lowest: compounds 1, 3, 4 and 2 (each within the scatter of the next).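

In this assay, cyano in place of chloro on this aromatic carbon gives a 1.1-fold higher number from compound 3 to compound 4 (0.06 log units; within the scatter), and cyano in place of hydrogen gives a 1.3-fold higher number from compound 1 to compound 4 (0.12 log units; within the scatter). Going by these compounds alone, until now chloro was the only group seen at this place, meta to a fused ring and para to a fused ring; a second group, with two heavy atoms, a triple bond and a hydrogen-bond acceptor, now also stays within the scatter of both chloro and hydrogen, so the assay separates none of the three at this carbon. No measurement at hand offers an explanation for this flat result.

The compounds shown leave open whether an amine, a carboxylic acid or a longer chain on this same carbon would give a number beyond the scatter of compound 1, or whether this place simply shows little response to any group. Going by these compounds, it also remains open whether any single change to the shared core can move this read-out clearly, as every step seen so far lies within the scatter.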